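The compounds below may be only part of what the source reports. "The series", "measured", "known", "first", "only" and "open" are said of these compounds alone.

Measured compounds:
compound 1 `CCN(Cc1cccs1)C(=O)/C=C/c1ccc(C)cc1`: 2 nM
compound 2 `Cc1ccc(OCC(=O)N(C)Cc2cccs2)cc1`: 400 nM
compound 3 `CCN(Cc1cccs1)C(=O)C(C)(C)Oc1ccc(C)cc1`: 11000 nM

In an assay on HEK293 cells for agonist activity at transient receptor potential cation channel subfamily M member 8 (Homo sapiens), read by fluorescence and calcium flux, with a stated time of 15 min (a higher number here means that more compound is needed for the effect, a lower number that less compound is needed), compound 1 gives 2 nM, compound 2 gives 400 nM and compound 3 gives 11000 nM. Compound 2 has the second highest of the three numbers: compound 3 lies well above it, beyond the scatter, and compound 1 lies far below it, also beyond the scatter. Compound 4 `Cc1ccc(OCC(=O)N(Cc2cccs2)c2cn[nH]c2)cc1` has not yet been measured. It differs from compound 2 in one place: 1H-pyrazol-4-yl in place of methyl on an amide-type nitrogen. Among the measured compounds shown here, no two measured compounds differ in only one place, so there is no directly comparable step to lean on. A modest rise in the number, somewhat beyond the scatter, is expected; the expected step in this assay is a 2.0-fold higher number from compound 2 to compound 4 (0.30 log units; within the scatter). Compound 4 is estimated at 800 nM, with a range from 120 nM to 5000 nM.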

Compound 4, half-maximal effective concentration: 1.4 nM
Beside the measured number, compound 4's estimate is 570-fold (2.76 log units) above it; the measured number lies below the stated range.
By their numbers in this assay, from the lowest: compounds 4 and 1 (each within the scatter of the next); then compound 2; then compound 3.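

In this assay, among the compounds shown here, the amide-type nitrogen proves to be a highly sensitive position: 1H-pyrazol-4-yl in place of methyl gives a 290-fold lower number from compound 2 to compound 4 (2.46 log units; beyond the scatter) and is the first single-place change that can be read in this set. This nitrogen therefore tolerates a five-membered aromatic ring with 2 hetero atoms, and the change brings the number down sharply. Nothing shown explains this step. From the compounds shown here alone, whether a plain phenyl ring on this nitrogen would give a similar drop remains open, and so does the effect of a longer chain such as propyl.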